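This account rests on a few compounds, and the source may have more. Where it says the series, first, only, none or still open, it means among the compounds named here.

Compound 3 `Cn1ncc(Cl)c1-c1cc(C(=O)N[C@@H]2CN[C@H](CC(=O)NC3CC3)C[C@H]2c2ccc(Cl)c(Cl)c2)oc1Cl` carries a cyclopropylcarbamoyl group on a saturated chain carbon bound to a saturated ring carbon. In an assay for inhibition of RAC-alpha serine/threonine-protein kinase (Homo sapiens), read by HTRF, with a stated time of 1 h (on this read-out lower numbers stand for stronger inhibition and higher numbers for weaker inhibition), compound 3 gives 3.95 nM. Among the measured compounds it sits second highest: compound 1 `Cn1ncc(Cl)c1-c1cc(C(=O)N[C@@H]2CN[C@H](CC(O)CO)C[C@H]2c2ccc(Cl)c(Cl)c2)oc1Cl` is nearest with 3.79 nM, and compound 2 `Cn1ncc(Cl)c1-c1cc(C(=O)N[C@@H]2CN[C@H](CCn3cncn3)C[C@H]2c2ccc(Cl)c(Cl)c2)oc1Cl` is furthest with 4.47 nM, both gaps lying within the scatter.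

Compound 4 `COCC[C@@H]1C[C@@H](c2ccc(Cl)c(Cl)c2)[C@H](NC(=O)c2cc(-c3c(Cl)cnn3C)c(Cl)o2)CN1` has not yet been measured. It differs from compound 3 in one place: methoxymethyl in place of cyclopropylcarbamoyl on a saturated chain carbon bound to a saturated ring carbon.

Among the measured compounds shown here, all the measured steps touch this same position and all stay within the scatter. a 1.2-fold higher number from compound 1 to compound 2 (0.07 log units; within the scatter), and a 1.0-fold higher number from compound 1 to compound 3 (0.02 log units; within the scatter). Likewise, a 1.1-fold lower number from compound 2 to compound 3 (0.05 log units; within the scatter). Three rather different groups at this position, 1,2-dihydroxyethyl, (1H-1,2,4-triazol-1-yl)methyl and cyclopropylcarbamoyl, therefore give numbers that cannot be told apart in this assay. The change to methoxymethyl, which keeps a hydrogen-bond acceptor but drops the donor and the ring, is expected to behave in the same way, with no step beyond the scatter in either direction.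

On that basis compound 4 is expected to give 4.5 nM in this assay, with a range from 2 nM to 10 nM. This estimate amounts to a 1.1-fold higher number from compound 3 to compound 4 (0.06 log units; within the scatter), which is expected to stay within the scatter.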

Compound 4, half-maximal inhibitory concentration: 7.01 nM
Beside the measured number, compound 4's estimate is 1.6-fold (0.19 log units) below it, within the range that was stated.
By their numbers in this assay, from the lowest: compounds 1, 3, 2 and 4 (each within the scatter of the next).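

In this assay methoxymethyl, which has no ring, no hydrogen-bond donor and 3 heavy atoms against the 6 of cyclopropylcarbamoyl, stays within the scatter (a 1.8-fold higher number from compound 3 to compound 4 (0.25 log units; within the scatter)). The same holds against the other two groups (a 1.6-fold higher number from compound 2 to compound 4 (0.20 log units; within the scatter); a 1.8-fold higher number from compound 1 to compound 4 (0.27 log units; within the scatter)), so the four compounds still cannot be told apart and the position on a saturated chain carbon bound to a saturated ring carbon now spans a wider set of groups, including one without a ring and without a donor. The cyclopropane ring and the amide hydrogen of compound 3 are therefore not required for a number in this range, although no measurement available here explains this tolerance.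

The compounds shown leave open whether a primary amine or a carboxylic acid at this position, or a longer chain such as a 4-methoxybutyl group, would also stay within the scatter in this assay. They also leave open whether a bare methyl group would do so, which would show how little of the side chain is needed.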